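A Hydroxyl-Bearing Sulfonamide Chain in Growth Inhibition

The source may report more compounds than this note shows. Statements on the series, on what has been measured and on what is new or still open speak of the compounds shown alone.

compound 1 `CCC1C(=O)N(C)c2cnc(Nc3ccc(S(=O)(=O)NCC(C)C)cc3)nc2N1c1ccn(C)n1` at 7300 nM
compound 2 `CC[C@@H]1C(=O)N(C)c2cnc(Nc3ccc(S(=O)(=O)NC)cc3)nc2N1C1CCCC1` at 222 nM

In a functional assay on K562 cells (Homo sapiens) for antiproliferative activity, read by CCK-8 assay, with a stated time of 72 h (a higher number here means a weaker inhibitor of growth, a lower number a stronger inhibitor of growth), compound 1 stands at the higher of the two numbers, 7300 nM against compound 2 at 222 nM for a gap beyond the scatter. Compound 3 `CCC1C(=O)N(C)c2cnc(Nc3ccc(S(=O)(=O)NCCCO)cc3)nc2N1c1ccn(C)n1` keeps the core of compound 1 and carries 2-hydroxyethyl in place of isopropyl on a saturated chain carbon bound to a sulfonamide nitrogen, which also reads as isobutyl to 3-hydroxypropyl. Among the measured compounds shown here, no measured pair isolates this change, and compound 2 differs from compound 1 in more than one place. The estimate therefore rests on compound 1 at 7300 nM and leans only modestly toward a lower number in this assay. The expected step of a 2.1-fold lower number from compound 1 to compound 3 (0.32 log units; beyond the scatter) may not clear the scatter by much. For compound 3 the estimated value is 3500 nM with an expected range of 1000 nM to 12000 nM in this measurement.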

Compound 3, concentration for 50% growth inhibition: 13400 nM
Beside the measured number, compound 3's estimate is 3.8-fold (0.58 log units) below it; measured number outside the range, above it.
By their numbers in this assay, from the lowest: compound 2; then compounds 1 and 3 (each within the scatter of the next).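

On the core of compound 1, 2-hydroxyethyl in place of isopropyl on a saturated chain carbon bound to a sulfonamide nitrogen gives, in this assay, a 1.8-fold higher number from compound 1 to compound 3 (0.26 log units; within the scatter) and so no separation between the two compounds. At this position, then, the isobutyl chain, with no hydrogen-bond donor or acceptor, and the 3-hydroxypropyl chain, with one of each, cannot be told apart in this read-out. No measurement at hand offers an explanation for this result.

Going by these compounds, whether an amine, a carboxylic acid or a longer chain at the same place would also stay within the scatter of compound 1 remains open. Compound 2 differs from compound 1 in more than one place, so the compounds shown do not tie its lower number to any single change.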